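Shifting the methoxy pattern on a dienone cytotoxic agent

The source may report more compounds than this note shows. Statements on the series, on what has been measured and on what is new or still open speak of the compounds shown alone.

Compound 2 `COc1ccc(/C=C/C(=O)/C=C/c2ccc(OCc3cn(CCOc4cc(=O)oc5ccccc45)nn3)c(OC)c2)cc1OC` is tested in a functional assay on HCT-116 cells (Homo sapiens) for cytotoxicity, read by sulforhodamine B assay, with a stated time of 48 h (on this read-out lower numbers stand for stronger inhibition and higher numbers for weaker inhibition), where compound 2 gives 4710 nM, the lowest of the two numbers seen so far. The other measured compound, compound 1 `COc1cccc(/C=C/C(=O)/C=C/c2ccc(OCc3cn(CCOc4cc(=O)oc5ccccc45)nn3)c(OC)c2)c1`, gives 9760 nM in this assay. For the measured compounds named here, the only measured step, a 2.1-fold lower number from compound 1 to compound 2 (0.32 log units; beyond the scatter), came from methoxy in place of hydrogen on an aromatic carbon. Compound 3 `COc1ccccc1/C=C/C(=O)/C=C/c1ccc(OCc2cn(CCOc3cc(=O)oc4ccccc34)nn2)c(OC)c1` is not yet measured; its change from compound 2 is 2-methoxyphenyl in place of 3,4-dimethoxyphenyl on a double-bonded chain carbon bound to a double-bonded chain carbon. This change reverses part of the earlier step, so compound 3 is expected to show a modest move back toward compound 1, with a 1.7-fold higher number from compound 2 to compound 3 (0.23 log units; within the scatter) as the estimated step. Compound 3 is estimated at 8000 nM, within 3500 nM to 18000 nM.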

Compound 3, half-maximal inhibitory concentration: 9490 nM
Estimate against measurement, compound 3: 1.2-fold (0.07 log units) below; the measured number falls inside the stated range.
By their numbers in this assay, from the lowest: compounds 2, 3 and 1 (each within the scatter of the next, the first and the last beyond it).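

In this assay, putting 2-methoxyphenyl in place of 3,4-dimethoxyphenyl on a double-bonded chain carbon gives a 2.0-fold higher number from compound 2 to compound 3 (0.30 log units; within the scatter), so this change cannot be told apart from repeat-measurement noise. Putting 2-methoxyphenyl in place of 3-methoxyphenyl gives a 1.0-fold lower number from compound 1 to compound 3 (0.01 log units; within the scatter), so these two single-methoxy groups read alike at this place. Nothing available explains these results.

Still open, from the compounds shown here alone, is how this number would respond to a plain phenyl group, or to a phenyl ring carrying an amine or a carboxylic acid, at this place.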